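The source may report more compounds than this note shows. Statements on the series, on what has been measured and on what is new or still open speak of the compounds shown alone.

Working notes on the naphthyloxyacetyl hydrazone series, read in an ADME assay on HEL cells (Homo sapiens) for cytotoxicity; on this read-out lower numbers stand for higher toxicity in this test and higher numbers for lower toxicity in this test. Three compounds carry a measured number. Compound 1, `C/C(=N\NC(=O)COc1cccc2ccccc12)c1ccc(C#N)cc1Br`, gives 20 ug/mL. Compound 2, `O=C(COc1cccc2ccccc12)N/N=C/c1c(O)ccc2ccccc12`, gives 4 ug/mL. Compound 3, `O=C(COc1cccc2ccccc12)N/N=C/c1ccccc1[N+](=O)[O-]`, gives 20 ug/mL.

On these numbers compound 3 stands level with compound 1 at the digits shown, the pair together giving the highest numbers of the three, so the two sit within the scatter of each other and no order between them can be claimed. Compound 2 gives a lower number than compound 3, and this gap lies beyond the scatter.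

The next compound, compound 4, `O=C(COc1cccc2ccccc12)N/N=C/c1ccccc1Cl`, has not yet been measured in this assay. It differs from compound 3 in one place: chloro in place of nitro on an aromatic carbon. Within the data shown here, no step between measured compounds covers this exact change, so the expectation rests only on where compound 3 stands and on the spread across compounds 1 to 3.

With compound 3 at 20 ug/mL and compound 1 at the same number, the step from compound 3 to compound 4 is expected to be small, no change at the digits printed from compound 3 to compound 4 (within the scatter), not beyond the scatter in either direction. Compound 4 is therefore estimated at 20 ug/mL, with a range from 6 ug/mL to 50 ug/mL.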

Compound 4, minimum cytotoxic concentration: 100 ug/mL
Compound 4: middle estimate off by 5.0-fold (0.70 log units), on the low side; the whole stated range lies below it.
By their numbers in this assay, from the lowest: compound 2; then compounds 1 and 3 (each within the scatter of the next); then compound 4.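

Among these compounds, the exchange of nitro for chloro on an aromatic carbon, ortho to a large group, gives a 5.0-fold higher number from compound 3 to compound 4 (0.70 log units; beyond the scatter) in this assay and is the first step that can be read in one place. Compounds 1 to 3 differ in more than one place, so their numbers could not show what a single group contributes; this pair shows that changing only the group at this position can move the read-out beyond the scatter, and by more than the estimate drawn from those compounds allowed. No measurement at hand bears on why this exchange moves the number, and the step stands as an observation only.

A single pair leaves open how the read-out follows the group at this position, and whether an amine, a carboxylic acid, a methoxy group or a plain hydrogen would fall nearer compound 3 or compound 4. It also leaves open whether the same exchange would give a step of similar size on the core of compound 1 or compound 2, or with chloro placed elsewhere on the ring.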